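The source may hold more compounds than are shown below. What is called first, only, known or untested is meant among the compounds shown, and "the series" means these compounds.

Measured so far, in a functional assay on HL-60 cells (Homo sapiens) for cytotoxicity, read by WST assay, with a stated time of 48 h; on this read-out lower numbers stand for stronger inhibition and higher numbers for weaker inhibition:

Compound 1, `O[C@@H](c1ccccc1)[C@H]1CO[C@H](c2ccccc2)[C@@H](C/C=C/c2ccncc2)C1`: > 100000 nM
Compound 2, `COc1cccc(/C=C/C[C@H]2C[C@@H]([C@@H](O)c3ccccc3)CO[C@@H]2c2ccccc2)c1`: 9620 nM
Compound 3, `O[C@@H](c1ccccc1)[C@H]1CO[C@H](c2ccccc2)[C@@H](C/C=C/c2ccccc2)C1`, gives 7040 nM.

Compound 1 sits at a limit of the assay, not at a number, and this is the limit at which compound 1 sits: the limit of > 100000 nM in this assay, at which 1 of the 3 values shown sits. Among the two real numbers, compound 3 gives the lowest, and compound 2 lies next to it with a difference of a 1.4-fold lower number from compound 2 to compound 3 (0.14 log units; within the scatter), so the two cannot be told apart. Against compound 1 the gaps are large: an at least 14-fold lower number from compound 1 to compound 3 (1.15 log units; beyond the scatter) and an at least 10-fold lower number from compound 1 to compound 2 (1.01 log units; beyond the scatter). Both of these steps change only the aromatic group on the double-bonded chain carbon, so this group matters.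

Compound 4, `C=CC[C@H]1C[C@@H]([C@@H](O)c2ccccc2)CO[C@@H]1c1ccccc1`, has not been measured. It differs from compound 3 in this way: vinyl in place of 2-phenylethenyl on a saturated chain carbon bound to a saturated ring carbon. Within the data shown here, no measured step removes the aromatic group altogether, so the size of the effect is uncertain, but the two large steps just described show that changes at this part of the molecule can move the number strongly. A weakening is therefore expected for compound 4, a 7.1-fold higher number from compound 3 to compound 4 (0.85 log units; beyond the scatter). The estimate for compound 4 in this assay is 50000 nM, within a range from 10000 nM to 200000 nM.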

Compound 4, half-maximal inhibitory concentration: 36000 nM
The estimate for compound 4 lay 1.4-fold (0.14 log units) above the measured number; measured number inside the range.
By their numbers in this assay, from the lowest: compounds 3 and 2 (each within the scatter of the next); then compound 4. At a limit, above all of these: compound 1.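

In this assay, cutting the chain back to allyl removes the aromatic ring entirely and still leaves a measurable number, but the number rises: a 5.1-fold higher number from compound 3 to compound 4 (0.71 log units; beyond the scatter), and a 3.7-fold higher number from compound 2 to compound 4 (0.57 log units; beyond the scatter). A phenyl or 3-methoxyphenyl ring on this chain therefore goes with a lower number, though no ring is needed for a measurable value. Pyridin-4-yl goes against this pattern, doing worse than no ring at all, an at least 2.7-fold lower number from compound 1 to compound 4 (0.44 log units; beyond the scatter), and compound 1 stands at a limit, not at a number: the limit of > 100000 nM in this assay, at which 1 of the 4 values shown sits.

Still open, as far as these compounds go, is whether a saturated propyl chain, a longer chain without a ring, or an amine at the chain end would behave like the allyl group of compound 4 or like the ring-bearing chains. Also open, from the compounds shown here alone, is whether a hydroxyl or a chlorine on the phenyl ring could bring the number clearly below those of compound 2 and compound 3.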